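Solubility notes: acetamido to dimethylamino on the side chain

A few compounds are considered here, and "the series" means these few. Any claim that something is new, unique, unknown or untested is made for them only; others in the source may bear on it.

Measured in a physicochemical assay for solubility; a lower number here means a less soluble compound, a higher number a more soluble compound:
compound 1 `CC(=O)N1CCc2c(C)c3c(n2-c2ccc(C(N)=O)c(c2)N[C@@H](C)CC1)CC(C)(C)CC3=O` — 19 ug/mL
compound 2 `CC(=O)NCCN1CC[C@H](C)Nc2cc(ccc2C(N)=O)-n2c(c(C)c3c2CC(C)(C)CC3=O)CC1=O` — > 100 ug/mL
compound 3 `Cc1c2c(n3c1CCN(C(=O)[C@@H](C)N)CC[C@H](C)Nc1cc-3ccc1C(N)=O)CC(C)(C)CC2=O` — > 100 ug/mL

Compound 2 gives > 100 ug/mL in this assay, which is a limit of the assay and not a number. Compound 3 likewise gives > 100 ug/mL, also a limit. Compound 2 therefore sits at the limit of > 100 ug/mL in this assay, at which 2 of the 3 values shown sit. Compound 4 `Cc1c2c(n3c1CC(=O)N(CCN(C)C)CC[C@H](C)Nc1cc-3ccc1C(N)=O)CC(C)(C)CC2=O` is not yet measured; it differs from compound 2 by dimethylamino in place of acetamido on a saturated chain carbon, two bonds along the chain from an amide-type nitrogen in a ring. Among the measured compounds shown here, the only measured step, an at least 5.2-fold higher number from compound 1 to compound 3 (0.72 log units; beyond the scatter), concerns a different change and does not bear directly on this one. For the measured compounds named here, no measured step reports a shift at this position, so the step of a number no higher from compound 2 to compound 4 (the limit leaves the size open) is expected to be none beyond the scatter. Compound 4 is expected at 100 ug/mL, within a range of 40 ug/mL to 250 ug/mL.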

Compound 4, solubility: > 100 ug/mL
Compound 4 was reported as a limit; the forecaster's own chance of this, stated with the estimate: 60%; the middle value sits exactly at the limit.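

In this assay compound 4 gives > 100 ug/mL, a limit and not a number. Compound 2 gives > 100 ug/mL, also a limit, so no step can be read between compound 2 and compound 4. The compounds shown leave open how far either compound lies past that limit, and whether acetamido and dimethylamino differ at all in this assay.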